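Aspirin-bearing bicyclic diesters: aromatic to nitrooxyethyl acyl swap

A few compounds are considered here, and "the series" means these few. Any claim that something is new, unique, unknown or untested is made for them only; others in the source may bear on it.

Three diesters on the shared core of compound 1 `CC(=O)Oc1ccccc1C(=O)O[C@H]1CO[C@H]2[C@@H]1OC[C@H]2OC(=O)c1cccc(C)c1` have been run in an ADME assay on a cell-free system (plasma, Homo sapiens) for metabolic stability, with Plasma (Rattus norvegicus) as the target, read by HPLC, at pH 7.4; on this read-out lower numbers stand for a shorter-lived compound and higher numbers for a longer-lived compound. In this assay compound 1 gives 0.0203 h, compound 2 `CC(=O)Oc1ccccc1C(=O)O[C@H]1CO[C@H]2[C@@H]1OC[C@H]2OC(=O)c1ccc(C)cc1` gives 0.0362 h, and compound 3 `COc1ccc(C(=O)O[C@@H]2CO[C@H]3[C@@H]2OC[C@@H]3OC(=O)c2ccccc2OC(C)=O)cc1` gives 0.0183 h. Compound 3 sits within the scatter of both neighbours: a 1.1-fold lower number from compound 1 to compound 3 (0.05 log units; within the scatter) and a 2.0-fold lower number from compound 2 to compound 3 (0.30 log units; within the scatter), and the remaining pair shows a 1.8-fold higher number from compound 1 to compound 2 (0.25 log units; within the scatter). Thus the three aromatic esters are indistinguishable on this read-out.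

Compound 4 `CC(=O)Oc1ccccc1C(=O)O[C@H]1CO[C@H]2[C@@H]1OC[C@H]2OC(=O)CCO[N+](=O)[O-]` differs from compound 3 as follows: 2-(nitrooxy)ethyl in place of 4-methoxyphenyl on a carbonyl carbon. Every measured step exchanges one substituted phenyl for another on the same carbonyl carbon, and each stayed within the scatter; none swaps an aromatic group for an open chain such as the 2-(nitrooxy)ethyl group. The measured steps therefore give no direction for this change, only a baseline near compound 3.

The expectation for compound 4 in this assay is 0.02 h, with a range of 0.006 h to 0.07 h, i.e. an estimated step of a 1.1-fold higher number from compound 3 to compound 4 (0.04 log units; within the scatter), widened to allow for the unprecedented change.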

Compound 4, half-life: 0.0217 h
Compound 4: middle estimate off by 1.1-fold (0.04 log units), on the low side; the measured number falls inside the stated range.
By their numbers in this assay, from the lowest: compounds 3, 1, 4 and 2 (each within the scatter of the next).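

In this assay, the carbonyl carbon takes an open chain as readily as a substituted phenyl, with all three new steps inside the scatter: (  a 1.2-fold higher number from compound 3 to compound 4 (0.07 log units; within the scatter)), (a 1.7-fold lower number from compound 2 to compound 4 (0.22 log units; within the scatter)) and (a 1.1-fold higher number from compound 1 to compound 4 (0.03 log units; within the scatter)). Across these four compounds, then, an aromatic ring at this position is not required for a half-life in this range, and 2-(nitrooxy)ethyl cannot be told apart from the three aromatic groups. No measurement at hand accounts for this result.

Going by these compounds, whether a chain bearing an amine, a carboxylic acid or a longer nitrooxy chain on this carbonyl carbon would move the half-life beyond the scatter stays open. The half-life alone also does not say which ester of the diester is lost first.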